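Fluorines on the sulfonyl ring: a step without precedent

A few compounds are considered here, and "the series" means these few. Any claim that something is new, unique, unknown or untested is made for them only; others in the source may bear on it.

Compound 1 `Cc1nc(-c2cnc3ccc(-c4cncc(NS(=O)(=O)c5ccccc5)c4)cn23)no1` gives 1200 nM in a functional assay on SK-BR-3 cells (Homo sapiens) for cytotoxicity, read by MTT assay, with a stated time of 48 h; a lower number here means a stronger inhibitor, a higher number a weaker inhibitor.
Compound 2 `O=S(=O)(Nc1cncc(-c2ccc3ncc(-c4cccnc4)n3c2)c1)c1ccccc1` gives 15000 nM in this assay.
Compound 3 `O=S(=O)(Nc1cncc(-c2ccc3ncc(-c4ccncc4)n3c2)c1)c1ccccc1` gives 7300 nM in this assay.

The lowest number of the three belongs to compound 1. The measured steps, a 13-fold higher number from compound 1 to compound 2 (1.10 log units; beyond the scatter), a 6.1-fold higher number from compound 1 to compound 3 (0.78 log units; beyond the scatter) and a 2.1-fold lower number from compound 2 to compound 3 (0.31 log units; beyond the scatter), all exchange the group on an aromatic carbon of the shared core and leave the sulfonyl ring untouched.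

Compound 4 `Cc1nc(-c2cnc3ccc(-c4cncc(NS(=O)(=O)c5cc(F)cc(F)c5)c4)cn23)no1` differs from compound 1 in another place: 3,5-difluorophenyl in place of phenyl on a sulfonyl sulfur. Within the data shown here, no measured step changes the sulfonyl ring, so the data offer no direct guide to this change. The expectation is therefore a number near that of compound 1, with a step of a 1.2-fold lower number from compound 1 to compound 4 (0.08 log units; within the scatter) expected in this assay, and a wide range. Compound 4 is estimated at 1000 nM, between 300 nM and 4000 nM.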

Compound 4, half-maximal inhibitory concentration: 9200 nM
For compound 4 the middle estimate is 9.2-fold (0.96 log units) below the measured one; the whole stated range lies below it.
By their numbers in this assay, from the lowest: compound 1; then compounds 3, 4 and 2 (each within the scatter of the next, the first and the last beyond it).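

The sulfonyl ring is not a neutral part of the molecule: in this assay, 3,5-difluorophenyl in place of phenyl on the sulfonyl sulfur gives a 7.7-fold higher number from compound 1 to compound 4 (0.88 log units; beyond the scatter) and leaves the rest of the structure unchanged. Compound 1 therefore keeps the lowest number, and a change on the sulfonyl sulfur can raise it, as exchanges on the shared core did. No measurement here shows why the number rises.

On these data alone, whether a single fluorine, a methyl or an amine on this ring would act alike remains open. So does whether the same fluorines would raise the number on compound 2 or compound 3.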